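The source may report more compounds than this note shows. Statements on the series, on what has been measured and on what is new or still open speak of the compounds shown alone.

Measured compounds:
- compound 1, `CCc1ccc(NC(=O)Nc2cc(C)nc3ccccc23)cc1`: 535 10^-6 cm/s
- compound 2, `Cc1cc(NC(=O)Nc2ccc3[nH]cnc3c2)c2ccccc2n1`: 2 10^-6 cm/s
- compound 3, `Cc1cc(NC(=O)Nc2cnc3ccccc3c2)c2ccccc2n1`: 46 10^-6 cm/s

Three compounds share a core and differ in the ring attached to the urea. In an ADME assay for permeability, using PAMPA, at pH 7.4 (on this read-out lower numbers stand for lower permeability and higher numbers for higher permeability), compound 1 gives 535 10^-6 cm/s, the highest of the three numbers. Compound 3 gives 46 10^-6 cm/s. This number is lower than that of compound 1, with a gap beyond the scatter. Compound 2 gives 2 10^-6 cm/s. This number is lower still, and its gap to compound 1 is also beyond the scatter. No two of these compounds differ in only one place, so no single step can be read off from them; the numbers only show how widely this read-out varies across the set.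

Compound 4, `Cc1cc(NC(=O)Nc2ccc(O)cc2)c2ccccc2n1`, has not yet been measured in this assay. It differs from compound 1 in one place: hydroxy in place of ethyl on an aromatic carbon. Given the spread between compound 1 and the other two, a drop beyond the scatter is expected, an 8.9-fold lower number from compound 1 to compound 4 (0.95 log units; beyond the scatter). Compound 4 is therefore estimated at 60 10^-6 cm/s, with a range from 15 10^-6 cm/s to 200 10^-6 cm/s.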

Compound 4, apparent permeability: 3 10^-6 cm/s
The estimate for compound 4 lay 20-fold (1.30 log units) above the measured number; measured number outside the range, below it.
By their numbers in this assay, from the lowest: compounds 2 and 4 (each within the scatter of the next); then compound 3; then compound 1.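

Within the data shown here, this is the first single change that can be read in this assay: with the rest of the molecule held the same, hydroxy in place of ethyl on this aromatic carbon, para to a large group, produces a 180-fold lower number from compound 1 to compound 4 (2.25 log units; beyond the scatter) and this step lies well beyond the scatter. The position is therefore not a silent one, since one small swap here can move the read-out a long way. The swap also replaces a group with no hydrogen-bond donors or acceptors by one with a donor and an acceptor, but nothing at hand shows why the number falls.

From the compounds shown here alone, with a single step at this position, it remains open whether the size of the drop is special to hydroxy. A methoxy group, an amine, a carboxylic acid or a longer chain in the same place would help to show how far the read-out follows the group there.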